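The compounds below may be only part of what the source reports. "The series", "measured", "known", "first", "only" and "open" are said of these compounds alone.

Compound 1 `CC(=O)N[C@@H]1CCC[C@H](C(=O)Nc2cc(-c3cnc4n3CCCC4)c(Cl)cn2)C1` and compound 2 `CC(=O)N[C@@H]1CCC[C@H](C(=O)Nc2cc(-c3cnn4c3CCCCC4)c(Cl)cn2)C1` share one core and differ only in the group carried on one aromatic carbon. In an ADME assay on cells (Hepatocyte, Rattus norvegicus) for metabolic stability, using equilibrium dialysis (a higher number here means faster removal of the compound, a lower number slower removal), compound 1 gives 12 uL/min, while compound 2 gives 51 uL/min. Among the measured compounds shown here, of these two numbers, compound 2 has the higher one, and its only neighbour is compound 1, reached by a 4.3-fold higher number from compound 1 to compound 2 (0.63 log units; beyond the scatter). Compound 3 `CC(=O)N[C@@H]1CCC[C@H](C(=O)Nc2cc(-c3cnn4c3OCCC4)c(Cl)cn2)C1` is not yet measured; it differs from compound 2 by a group of 9 heavy atoms (6 carbon, 2 nitrogen, 1 oxygen; one five-membered aromatic ring with 2 hetero atoms, one six-membered non-aromatic ring with 2 hetero atoms) in place of a group of 10 heavy atoms (8 carbon, 2 nitrogen; one five-membered aromatic ring with 2 hetero atoms, one seven-membered non-aromatic ring with 1 hetero atom), on an aromatic carbon.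

For the measured compounds named here, the only measured step that bears on this change is the one just described, in which a seven-membered non-aromatic ring took the place of a six-membered one and the number rose beyond the scatter. Going by the values given here, compound 3 moves the other way, back to a six-membered non-aromatic ring, though now with two hetero atoms in it rather than one, a feature no measured compound shows. A lower number than that of compound 2 is therefore expected, roughly toward where compound 1 lies, with some added uncertainty. Compound 3 is estimated at 18 uL/min, within a range from 7 uL/min to 45 uL/min. The estimated step is a 2.8-fold lower number from compound 2 to compound 3 (0.45 log units; beyond the scatter).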

Compound 3, intrinsic clearance in a liver preparation (reported as CLH), per the amount of preparation that the assay uses: 34 uL/min
For compound 3 the middle estimate is 1.9-fold (0.28 log units) below the measured one, and the stated range covers the measured number.
By their numbers in this assay, from the lowest: compound 1; then compounds 3 and 2 (each within the scatter of the next).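

In this assay, replacing the group with the seven-membered non-aromatic ring by the one with the six-membered non-aromatic ring with 2 hetero atoms gives a 1.5-fold lower number from compound 2 to compound 3 (0.18 log units; within the scatter), so this change does not separate compound 2 from compound 3. A six-membered non-aromatic ring in this group, ortho to the chloro group, therefore does not by itself bring the number down to that of compound 1: the comparison shows a 2.8-fold higher number from compound 1 to compound 3 (0.45 log units; beyond the scatter), even though both groups have 9 heavy atoms. No measurement is available that explains why these groups behave as they do in this assay.

The groups of compound 1 and compound 3 differ in more than one feature, including an oxygen in the non-aromatic ring of compound 3 and a different arrangement of atoms in the two fused rings, so the compounds shown cannot say which feature accounts for the step between them. From the compounds shown here alone, it also remains open how the number would respond to a sulfur in place of that oxygen, or to an amine on the non-aromatic ring.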